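Sulfide and sulfoxide amines: benzoyl to pivaloyl step

The source may hold more compounds than are shown below. What is called first, only, known or untested is meant among the compounds shown, and "the series" means these compounds.

Measured so far:
compound 1 `[O-][S+](CCNC1CCN(Cc2ccc(F)cc2)CC1)C(c1ccc(F)cc1)c1ccc(F)cc1` gives 76800 nM
compound 2 `[O-][S+](CCNC1CCN(CC(O)Cc2ccccc2)CC1)C(c1ccc(F)cc1)c1ccc(F)cc1` gives "not determined" (no result reported)
compound 3 `O=C(c1ccccc1)N1CCC(NCCSC(c2ccc(F)cc2)c2ccc(F)cc2)CC1` gives 4110 nM

In an assay on membranes from HEK293 cells for displacement of a labelled ligand from D(4) dopamine receptor (Homo sapiens), read by scintillation counting, with a stated time of 60 min (a lower number here means a stronger inhibitor, a higher number a weaker inhibitor), compound 3 has the lowest number of the two values reported. Its nearest neighbour is compound 1, whose result in this assay is a markedly higher number, and that gap lies beyond the usual scatter; compound 3 and compound 1 differ in more than one place, so the gap is not traced to a single change. Compound 2 has no number in this assay, and nothing follows from it.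

The next compound, compound 4 `CC(C)(C)C(=O)N1CCC(NCCSC(c2ccc(F)cc2)c2ccc(F)cc2)CC1`, is compound 3 with one change: tert-butyl in place of phenyl on a carbonyl carbon. Among the compounds with values here, no step of this kind is recorded among the measured compounds, so the direction rests on general expectation only. The benzoyl group of compound 3 is traded for a smaller, non-aromatic acyl group; the amide itself stays. A moderate loss of binding is expected, of a size that may or may not clear the scatter: the step of a 2.2-fold higher number from compound 3 to compound 4 (0.34 log units; beyond the scatter) is the estimate. On that basis compound 4 is expected to give about 9000 nM in this assay, within a range from 3000 nM to 30000 nM.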

Compound 4, inhibition constant: 11900 nM
For compound 4 the middle estimate is 1.3-fold (0.12 log units) below the measured one; the measured number falls inside the stated range.
By their numbers in this assay, from the lowest: compound 3; then compound 4; then compound 1.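

In this assay, within the data shown here, the step of a 2.9-fold higher number from compound 3 to compound 4 (0.46 log units; beyond the scatter) is the first single-change comparison, and it places the acyl group, on a carbonyl carbon whose other neighbours are an amide-type nitrogen in a ring, among the parts that move the number. The move is modest but beyond the scatter, so the phenyl is not essential for a measurable value at this position: tert-butyl, with no ring and fewer heavy atoms, still gives a number well short of the highest in the set, while the amide and the rest of the molecule stay unchanged. No measured evidence on the origin of this shift is available, and it stands as an observation only.

A single pair cannot separate the loss of the aromatic ring from the specific effect of tert-butyl, and a cyclohexyl or a methyl on the same carbonyl carbon would bear on that question. Going by these compounds, the contribution of the sulfoxide also remains open, as compound 1 and compound 3 differ in more than one place, and a sulfoxide counterpart of compound 3 would isolate that single change.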